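This account rests on a few compounds, and the source may have more. Where it says the series, first, only, none or still open, it means among the compounds named here.

Compound 1, `CCOc1cc(OC)c(Br)cc1C(C)=O`, gives 46800000 nM in a functional assay, with a stated time of 30 min; on this read-out higher numbers stand for weaker inhibition and lower numbers for stronger inhibition.
Compound 2, `CCCCOc1cc(OC)c(Br)cc1C(C)=O`, gives 42300000 nM in this assay.
Compound 3, `CCCCCCCCCCCCCCOc1cc(OC)ccc1C(C)=O`, gives 43600000 nM in this assay.

All three numbers are very large, and they sit within the scatter of one another. The change from compound 1 to compound 2 is ethyl in place of hydrogen on a saturated chain carbon, two bonds along the chain from an oxygen on an aromatic ring, and it gave a 1.1-fold lower number from compound 1 to compound 2 (0.04 log units; within the scatter). Compound 3 carries a different core from compound 1; the difference between the two cores is not broken down here.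

Compound 4, `CCCCCCCCCCCCCCCCOc1cc(OC)ccc1C(C)=O`, has not yet been measured. It differs from compound 3 by ethyl in place of hydrogen on a saturated chain carbon, ten or more bonds along the chain from an oxygen on an aromatic ring. Within the data shown here, this is the same kind of change as the one from compound 1 to compound 2, but the place along the chain is not identical, as the two differences just given show. Since the earlier step stayed within the scatter, a similarly small step is expected from compound 3 to compound 4, namely a 1.0-fold lower number from compound 3 to compound 4 (0.02 log units; within the scatter). Compound 4 is therefore estimated at 42000000 nM in this assay, between 28000000 nM and 65000000 nM.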

Compound 4, half-maximal inhibitory concentration: 39400000 nM
The estimate for compound 4 lay 1.1-fold (0.03 log units) above the measured number, within the range that was stated.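

In this assay, ethyl in place of hydrogen on a saturated chain carbon, ten or more bonds along the chain from an oxygen on an aromatic ring, gives a 1.1-fold lower number from compound 3 to compound 4 (0.04 log units; within the scatter). Set beside the step on the other core, this step does not differ from it: the same change on two cores in this assay, a 1.1-fold lower number (0.04 log units; within the scatter) from compound 1 to compound 2 and a 1.1-fold lower number (0.04 log units; within the scatter) from compound 3 to compound 4, 1.0-fold (0.00 log units) apart, within the scatter of two such steps. So lengthening the chain leaves the number unchanged within the scatter on both cores, but this rests on only two pairs, which differ in the place of the change as well as in the core, and it does not show that the result would hold on any other core.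

The compounds shown leave open whether a chain carrying an amine or a carboxylic acid, rather than a plain carbon chain, would move these very large numbers. Also open, from the compounds shown here alone, is whether a chain as short as that of compound 1 would give a similar number on the core of compound 3.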